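Series notes: cyclopentylamino in place of the anilino group

The source may report more compounds than this note shows. Statements on the series, on what has been measured and on what is new or still open speak of the compounds shown alone.

Measured compounds in a functional assay on ECa-109 cells for inhibition, with ECa-109 cell line (Homo sapiens) as the target, read by sulforhodamine B assay; on this read-out lower numbers stand for stronger inhibition and higher numbers for weaker inhibition:
- compound 1 `Cc1ccc(NC2=CC(=O)c3nc4n(c3C2=O)[C@H]2OC[C@@H](O)[C@H]2OC4)cc1C`: 2820 nM
- compound 2 `Cc1ccc(NC2=CC(=O)c3c(nc4n3[C@H]3OC[C@@H](O)[C@H]3OC4)C2=O)cc1C`: 4090 nM
- compound 3 `Cc1ccc(NC2=CC(=O)c3c(nc4n3[C@H]3OC[C@@H](O)[C@H]3OC4)C2=O)cc1`: only a limit, > 4000 nM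

In this assay compound 1 gives 2820 nM, the lowest of the two numbers reported. Compound 2 gives 4090 nM, within the scatter of compound 1. For compound 3 the value > 4000 nM is a limit of the assay and not a number. The step that the limit leaves unreadable from compound 2 to compound 3 cannot be sized because one of its values sits at the limit of > 4000 nM in this assay, at which 1 of the 3 values shown sits.

Compound 4 `O=C1C=C(NC2CCCC2)C(=O)c2c1nc1n2[C@H]2OC[C@@H](O)[C@H]2OC1` differs from compound 1 by cyclopentyl in place of 3,4-dimethylphenyl on an amine nitrogen. Among the compounds with values here, no measured step bears on this change: the only step in the set concerns a methyl on the aromatic ring, and it is unreadable. The step from compound 1 to compound 4 is therefore expected to be small in either direction, with a wide range. Compound 4 is estimated at 4000 nM (from 1500 nM to 12000 nM) in this assay, an expected step of a 1.4-fold higher number from compound 1 to compound 4 (0.15 log units; within the scatter).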

Compound 4, half-maximal inhibitory concentration: > 16000 nM
Compound 4 was reported as a limit; the forecaster's own chance of this, stated with the estimate: 35%; middle value at least 4.0-fold (0.60 log units) from the limit.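

Cyclopentyl in place of 3,4-dimethylphenyl on the amine nitrogen gives an at least 5.6-fold higher number from compound 1 to compound 4 (0.75 log units; beyond the scatter) in this assay, the first step at this position that can be sized, since the only earlier step, a methyl on the aromatic ring, cannot be read. Going by these compounds, for compound 4 the reported value is a limit and not a number: the limit of > 16000 nM in this assay, at which 1 of the 4 values shown sits. The change therefore shows that, on the core of compound 1, this amine substituent cannot be exchanged for a saturated carbocycle without a loss of inhibition on this read-out, though the full size of the loss stays unknown.

The change swaps an aromatic ring for a non-aromatic one and also alters the ring size and the heavy-atom count, so these differences cannot be separated here. A cyclohexyl or benzyl group on the same nitrogen would help tell them apart.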